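Isopropyl in place of hydroxymethyl on the amino acid

The source may report more compounds than this note shows. Statements on the series, on what has been measured and on what is new or still open speak of the compounds shown alone.

In this series compound 3 `CC1=CCC[C@](C)(CC/C(C)=C/CC2=C(O)C(=O)C=C(N[C@H](CO)C(=O)O)C2=O)[C@@H]1C` sits at the assay limit: in an ADME assay on L1210 cells (Mus musculus) for cytotoxicity, with a stated time of 48 h (a lower number here means a stronger inhibitor, a higher number a weaker inhibitor), compound 3 gives > 10 ug/mL, a limit and not a number. Compound 1 `CC1=CCC[C@](C)(CC/C(C)=C/CC2=C(O)C(=O)C=C(N[C@@H](CO)C(=O)O)C2=O)[C@@H]1C` likewise gives > 10 ug/mL, again a limit. These two share every atom and bond and differ only in the configuration as drawn, so a step that the two limits leave unreadable from compound 1 to compound 3. For the measured compounds named here, compound 2 `CC1=CCC[C@](C)(CC/C(C)=C/CC2=C(O)C(=O)C=C(N[C@H](C(=O)O)C(C)C)C2=O)[C@@H]1C` gives 3.4 ug/mL, the one true number among the three, and an at least 2.9-fold lower number from compound 1 to compound 2 (0.46 log units; beyond the scatter); read the other way, an at least 2.9-fold higher number from compound 2 to compound 3 (0.46 log units; beyond the scatter).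

Compound 4 `CC1=CCC[C@](C)(CC/C(C)=C/CC2=C(O)C(=O)C=C(N[C@@H](C(=O)O)C(C)C)C2=O)[C@@H]1C` differs from compound 3 by isopropyl in place of hydroxymethyl on a saturated chain carbon bound to an amine nitrogen and a carbonyl carbon. Going by the values given here, the step that bears on it most directly is the one from compound 1 to compound 2, the same exchange carried out on the other drawn configuration, and it read as at least modest toward lower numbers. Because the limit of > 10 ug/mL in this assay, at which 2 of the 3 values shown sit, places both compound 1 and compound 3 together at the same limit, and because the fact that compounds 1 and 3 differ only in the configuration as drawn leaves no other difference between them, the same direction is expected here: an at least 2.8-fold lower number from compound 3 to compound 4 (0.45 log units; beyond the scatter), a fall of at least modest size, with the limit itself masking how large.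

Compound 4 is therefore estimated at 3.5 ug/mL in this assay, within a range from 1.5 ug/mL to 9 ug/mL.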

Compound 4, half-maximal inhibitory concentration: 3 ug/mL
The estimate for compound 4 lay 1.2-fold (0.07 log units) above the measured number; low and high end bracket the measured number.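

On the configuration of compound 3, isopropyl in place of hydroxymethyl on a saturated chain carbon bound to an amine nitrogen and a carbonyl carbon gives an at least 3.3-fold lower number from compound 3 to compound 4 (0.52 log units; beyond the scatter) in this assay, so the exchange now runs the same way on both drawn configurations, and the step with 1-carboxy-2-methylpropyl in place of 1-carboxy-2-hydroxyethyl on an amine nitrogen reads an at least 3.3-fold lower number from compound 1 to compound 4 (0.52 log units; beyond the scatter). For the compounds shown here, the isopropyl pair also supplies the first readable comparison of configuration at this carbon, a 1.1-fold lower number from compound 2 to compound 4 (0.05 log units; within the scatter), so the drawn configuration does not separate these two compounds. The two readings of the exchange agree in direction, but their sizes cannot be compared: the same change on two cores in this assay, an at least 2.9-fold lower number (0.46 log units; beyond the scatter) from compound 1 to compound 2 and an at least 3.3-fold lower number (0.52 log units; beyond the scatter) from compound 3 to compound 4; the limit leaves it open whether they differ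

Compounds 1 and 3 stand only as limits, so the full size of the exchange and any effect of configuration in the hydroxymethyl pair remain unread. Also open, going by these compounds, is whether a longer carbon chain, a benzyl group or an aminoalkyl chain at this place would follow the isopropyl compounds in this assay.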